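One benzyl swap on a shared core

The source may hold more compounds than are shown below. What is called first, only, known or untested is meant among the compounds shown, and "the series" means these compounds.

Compound 1 `COc1cc(OC)c(-c2coc3cc(OCc4ccc(Br)cc4)ccc3c2=O)cc1OC` gives 1050 nM in a functional assay on HepG2 cells (Homo sapiens) for antiproliferative activity, read by MTT assay, with a stated time of 24 h; a lower number here means a stronger inhibitor, a higher number a weaker inhibitor
Compound 2 `COc1cc(OC)c(-c2coc3cc(OCc4ccccc4Cl)ccc3c2=O)cc1OC` gives 1690 nM in this assay

Within the data shown here, compound 2 has a single neighbour on these numbers, and the one measured step, a 1.6-fold higher number from compound 1 to compound 2 (0.21 log units; within the scatter), leaves the two compounds level. Compound 3 `COc1cc(OC)c(-c2coc3cc(OCc4cccc(Br)c4)ccc3c2=O)cc1OC` keeps the shared core and changes one group, on a saturated chain carbon bound to an oxygen on an aromatic ring: 3-bromophenyl in place of 2-chlorophenyl on a saturated chain carbon bound to an oxygen on an aromatic ring. Put simply, 2-chlorobenzyl gives way to 3-bromobenzyl. Among the measured compounds shown here, the only evidence is that same measured step, which exchanged 4-bromophenyl for 2-chlorophenyl at this place. One step is thin support, but it gives no reason to expect a step beyond the scatter in this assay. Compound 3 carries bromine, as does compound 1 at 1050 nM, so a value between the two is expected. The expected step is a 1.3-fold lower number from compound 2 to compound 3 (0.11 log units; within the scatter) and no more. For compound 3 the estimated value is 1300 nM, with an expected range from 650 nM to 2600 nM.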

Compound 3, half-maximal inhibitory concentration: 870 nM
Compound 3: the middle estimate sits 1.5-fold (0.17 log units) above what was measured; low and high end bracket the measured number.
By their numbers in this assay, from the lowest: compounds 3, 1 and 2 (each within the scatter of the next).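

At this place, on a saturated chain carbon bound to an oxygen on an aromatic ring, three different groups have now been compared in this assay, and the new steps are a 1.9-fold lower number from compound 2 to compound 3 (0.29 log units; within the scatter) and a 1.2-fold lower number from compound 1 to compound 3 (0.08 log units; within the scatter). The second step keeps the bromine and only exchanges 4-bromophenyl for 3-bromophenyl, so this change of bromine placement, which the earlier pair could not test, does not rise above the scatter, and neither does the exchange of 2-chlorophenyl for 3-bromophenyl. Nothing further is available to explain this result.

All three groups are phenyl rings carrying chlorine or bromine, so they cover only a narrow range. On these data alone, how plain benzyl, a phenyl ring bearing an amine or a carboxylic acid, or a longer chain would read at this place remains open.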